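Swapping Phenyl for Quinolin-2-yl on a Ring Nitrogen

The source may report more compounds than this note shows. Statements on the series, on what has been measured and on what is new or still open speak of the compounds shown alone.

Three compounds built on one shared core have been examined in an assay on isolated protein for inhibition of Polyunsaturated fatty acid 5-lipoxygenase (Homo sapiens), read by HPLC, with a stated time of 15 min, in the presence of a further agent that is not named here; a higher number here means a weaker inhibitor, a lower number a stronger inhibitor. Compound 2 `CC(C)(C)c1ccc(CN2CCN(C(=O)CCc3cc(-c4ccc(F)cc4)n(-c4ccccc4)n3)CC2)cc1` gives 2500 nM in this assay, and compound 3 `CC(C)(C)c1ccc(CN2CCN(C(=O)CCc3cc(-c4ccc(C(F)(F)F)cc4)n(-c4ccccc4)n3)CC2)cc1` gives 2900 nM. For compound 1 `O=C(CCc1cc(-c2ccc(F)cc2)n(-c2ccc(Cl)nn2)n1)Oc1ccc(-n2ccnc2)cc1` the outcome in this assay is "not determined" (no result reported), so it contributes no number. For the measured compounds named here, the single change between the two measured compounds produces a 1.2-fold higher number from compound 2 to compound 3 (0.06 log units; within the scatter), a shift too small to carry meaning. Compound 3 therefore stands alongside compound 2, the two numbers indistinguishable once the scatter of repeated measurement is allowed for.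

Compound 4 `CC(C)(C)c1ccc(CN2CCN(C(=O)CCc3cc(-c4ccc(C(F)(F)F)cc4)n(-c4ccc5ccccc5n4)n3)CC2)cc1` differs from compound 3 in one place: quinolin-2-yl in place of phenyl on an aromatic nitrogen. Going by the values given here, none of the measured steps touches this position; the only step available concerns a different aromatic substituent and stayed within the scatter. There is thus no direct guide for this replacement, and the default expectation is no step beyond the scatter, held with a wide margin for surprise. Compound 4 is expected to give 2500 nM in this assay. The plausible range for compound 4 is estimated to run from 700 nM to 9000 nM. This corresponds to an expected step of a 1.2-fold lower number from compound 3 to compound 4 (0.06 log units; within the scatter).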

Compound 4, half-maximal inhibitory concentration: 3000 nM
For compound 4 the middle estimate is 1.2-fold (0.08 log units) below the measured one; measured number inside the range.
By their numbers in this assay, from the lowest: compounds 2, 3 and 4 (each within the scatter of the next).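

Putting quinolin-2-yl in place of phenyl on the aromatic nitrogen gives a 1.0-fold higher number from compound 3 to compound 4 (0.01 log units; within the scatter) in this assay. For the compounds shown here, the incoming group brings a further six-membered aromatic ring, this one holding a ring nitrogen, and a hydrogen-bond acceptor, yet this substantial change at a position that no earlier step had touched leaves no readable mark on the number, so the earlier step, a 1.2-fold higher number from compound 2 to compound 3 (0.06 log units; within the scatter), is now joined by a second single change that stays within the scatter, at a different place on the shared core. Nothing available here bears on the reason for this flat result.

The compounds shown place only two large aromatic groups on this nitrogen, so it remains open whether a small group such as methyl, or a phenyl carrying an amine, would move the number beyond the scatter. The part of compounds 2, 3 and 4 that carries the carbonyl is also the same throughout, which leaves unknown what a carboxylic acid or a longer chain at that end would do.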